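Cyclobutyl to oxetan-3-yl: working notes on compound 3

The compounds below may be only part of what the source reports. "The series", "measured", "known", "first", "only" and "open" are said of these compounds alone.

For the measured compounds named here, in an ADME assay on cells (Hepatocyte, Rattus norvegicus) for pharmacokinetics, read by LC-MS, with a stated time of 90 min, tested at 1 uM (a higher number here means faster removal of the compound, a lower number slower removal), compound 2 (`Nc1nc(-c2nn(Cc3ccccc3F)c3ncccc23)nc(N)c1NC(=O)OC1CCC1`) gives 23.3 mL/min/kg and is the highest of the two numbers so far. Going by the values given here, compound 1 (`COC(=O)Nc1c(N)nc(-c2nn(Cc3ccccc3F)c3ncccc23)nc1N`) gives 1.67 mL/min/kg and is its only neighbour on this scale. The change to compound 3 (`Nc1nc(-c2nn(Cc3ccccc3F)c3ncccc23)nc(N)c1NC(=O)OC1COC1`) is oxetan-3-yl in place of cyclobutyl on an oxygen next to a carbonyl group and keeps the place of the earlier change. Among the compounds with values here, the only measured step that bears on it is a 14-fold higher number from compound 1 to compound 2 (1.14 log units; beyond the scatter) and comes from methyl giving way to cyclobutyl. That step is large and beyond the scatter, so the number in this assay responds strongly to the group on this oxygen. Within the data shown here, no measured pair exchanges a ring carbon for a ring oxygen, so the direction here is a judgement and not a finding. A clear move toward a lower number is expected, smaller than the earlier step, with compound 3 still above compound 1. The estimate means a 3.3-fold lower number from compound 2 to compound 3 (0.52 log units; beyond the scatter) as the expected step. For compound 3 the estimated clearance is 7 mL/min/kg with an expected range of 2.5 mL/min/kg to 18 mL/min/kg in this assay.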

Compound 3, clearance: 1.67 mL/min/kg
The estimate for compound 3 lay 4.2-fold (0.62 log units) above the measured number; the measured number lies below the stated range.
By their numbers in this assay, from the lowest: compounds 1 and 3 (each within the scatter of the next); then compound 2.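

In this assay the exchange of cyclobutyl for oxetan-3-yl gives a 14-fold lower number from compound 2 to compound 3 (1.14 log units; beyond the scatter) and so takes back the whole of a 14-fold higher number from compound 1 to compound 2 (1.14 log units; beyond the scatter) at this position. Against the methyl compound the reading is no change at the digits printed from compound 1 to compound 3 (within the scatter), which shows that a four-membered ring on this oxygen does not by itself go with the higher number: with the ring size kept, a single ring oxygen in place of a ring carbon separates the two ends of the range seen so far. Nothing measured on these compounds explains the size of this step.

The three groups shown on this oxygen are methyl, cyclobutyl and oxetan-3-yl, so it stays open whether an open chain such as isopropyl, a larger ring such as tetrahydropyran-4-yl, or a ring holding an amine such as azetidin-3-yl would follow cyclobutyl or oxetan-3-yl in this read-out. Also open is whether the same exchange of cyclobutyl for oxetan-3-yl gives a step of this size on any core other than the shared core of these compounds.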